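Anilide variation in a cell growth inhibition series

This account rests on a few compounds, and the source may have more. Where it says the series, first, only, none or still open, it means among the compounds named here.

Compound 1 `COc1ccc2c(=O)c(/C=C/C(=O)Nc3cccc(Cl)c3)coc2c1` — in a functional assay on Huh-7 cells (Homo sapiens) for inhibition, read by MTT assay, with a stated time of 48 h (a lower number here means a stronger inhibitor, a higher number a weaker inhibitor), compound 1 reaches only the assay limit > 100000 nM.
Compound 2 `COc1ccc2c(=O)c(/C=C/C(=O)Nc3ccccc3Cl)coc2c1` — in this assay compound 2 gives 58400 nM.

Within the data shown here, compound 2 holds the only finite number so far; the other value is a limit. The step of an at least 1.7-fold lower number from compound 1 to compound 2 (0.23 log units; that floor lies within the scatter) rests on that limit (the limit of > 100000 nM in this assay, at which 1 of the 2 values shown sits) and gives no more than a floor. Compound 3 `COc1ccc2c(=O)c(/C=C/C(=O)Nc3cc(C)ccc3C)coc2c1` carries 2,5-dimethylphenyl in place of 2-chlorophenyl on an amide-type nitrogen. Among the measured compounds shown here, no measured step alters the group in this way, and the single step available lies within the scatter. For compound 3 the expected step of a 1.1-fold lower number from compound 2 to compound 3 (0.03 log units; within the scatter) is therefore none beyond the scatter. Compound 3 is estimated at 55000 nM, with a range from 15000 nM to 150000 nM.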

Compound 3, half-maximal inhibitory concentration: 11100 nM
Estimate against measurement, compound 3: 5.0-fold (0.70 log units) above, outside the stated range (below it).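

In this assay the group on the amide-type nitrogen now gives a step that can be read: a 5.3-fold lower number from compound 2 to compound 3 (0.72 log units; beyond the scatter) with 2,5-dimethylphenyl in place of 2-chlorophenyl. This place therefore moves the read-out beyond the scatter, which the two chlorophenyl compounds could not show. Compound 1 stands at a limit, so the step of an at least 9.0-fold lower number from compound 1 to compound 3 (0.95 log units; beyond the scatter) is a floor and no more: the limit of > 100000 nM in this assay, at which 1 of the 3 values shown sits.

Which of the two methyl groups carries the step remains open, since the change also removes the chlorine. Also open, from the compounds shown here alone, is how an amine or a carboxylic acid on this ring would read.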